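Vinylcarbonyl in Place of Cyclopropylsulfonyl on the Shared Core

This account rests on a few compounds, and the source may have more. Where it says the series, first, only, none or still open, it means among the compounds named here.

In a functional assay on LNCaP cells (Homo sapiens) for antiproliferative activity, read by MTT assay, with a stated time of 3 days (on this read-out lower numbers stand for stronger inhibition and higher numbers for weaker inhibition), compound 1 `COc1cc(O)c2c(=O)cc(-c3ccc(NS(C)(=O)=O)cc3)oc2c1OC(C)C` gives 15400 nM and compound 2 `COc1cc(O)c2c(=O)cc(-c3ccc(NS(=O)(=O)C4CC4)cc3)oc2c1OC(C)C` gives 8800 nM on the same read-out. Among the compounds with values here, these two values lie within the scatter of each other, so compound 2 cannot be ranked apart from compound 1 on the numbers so far. Compound 3 `C=CC(=O)Nc1ccc(-c2cc(=O)c3c(O)cc(OC)c(OC(C)C)c3o2)cc1` keeps the shared core of compound 2 and changes one place, with vinylcarbonyl in place of cyclopropylsulfonyl on a nitrogen on an aromatic ring, counted as vinylcarbonyl in place of cyclopropylsulfonyl on a nitrogen on an aromatic ring in this comparison. Within the data shown here, only one measured step bears on this change, and it bears loosely. The step of a 1.8-fold lower number from compound 1 to compound 2 (0.24 log units; within the scatter) came with cyclopropyl in place of methyl on a sulfonyl sulfur, whereas compound 3 has no sulfonyl group at all. Among the measured compounds shown here, no measured compound carries vinylcarbonyl, so the data offer no firm direction. No step beyond the scatter is expected in this assay and the estimate amounts to a 1.3-fold lower number from compound 2 to compound 3 (0.10 log units; within the scatter) for this change. For compound 3 the expected value is 7000 nM with an estimated range from 2000 nM to 20000 nM in this read-out.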

Compound 3, half-maximal inhibitory concentration: 15100 nM
Compound 3: middle estimate off by 2.2-fold (0.33 log units), on the low side; the measured number falls inside the stated range.
By their numbers in this assay, from the lowest: compounds 2, 3 and 1 (each within the scatter of the next).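

In this assay, the change at this nitrogen on an aromatic ring goes beyond swapping the group on a sulfonyl sulfur, and the sulfonyl group itself is gone: vinylcarbonyl in place of cyclopropylsulfonyl gives a 1.7-fold higher number from compound 2 to compound 3 (0.23 log units; within the scatter), and vinylcarbonyl in place of methylsulfonyl gives a 1.0-fold lower number from compound 1 to compound 3 (0.01 log units; within the scatter). Among these three compounds, then, the sulfonyl group can be absent from this nitrogen with no step beyond the scatter, and the smaller vinylcarbonyl, which has no ring, leaves compound 3 indistinguishable from both compound 1 and compound 2 on this read-out. Nothing measured here accounts for this result or ties it to any feature of either group.

The compounds shown leave open whether the double bond of the vinylcarbonyl plays any part in the value of compound 3, a question that an ethylcarbonyl group on the same nitrogen would address. No step shown lies beyond the scatter, so it also remains open whether any group on this nitrogen, such as an aminoacetyl group or a longer chain ending in a carboxylic acid, would separate from these three.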